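Aryl-thiophene sulfonamide series: urea-type terminus variation

The source may report more compounds than this note shows. Statements on the series, on what has been measured and on what is new or still open speak of the compounds shown alone.

Three compounds of the shared core carry a measured value in a functional assay on HL-60 cells (Homo sapiens) for inhibition, read by CCK-8 assay, with a stated time of 48 h; on this read-out higher numbers stand for weaker inhibition and lower numbers for stronger inhibition. Compound 1 `Cc1cc(C)cc(NC(=O)NCCNS(=O)(=O)c2ccc(-c3ccccc3OCc3ccccc3)s2)c1` gives 2200 nM. Compound 2 `COc1ccc(NC(=S)NCCNS(=O)(=O)c2sccc2-c2ccc(C)cc2Oc2ccc(O)c(O)c2)cc1` gives 4100 nM, the second highest of the three numbers. Its nearest neighbour is compound 1, whose number sits within the scatter of compound 2's, so no order between these two is claimed. Its furthest neighbour is compound 3 `O=C(NCCNS(=O)(=O)c1ccc(-c2ccccc2Oc2ccc(O)c(O)c2)s1)Nc1cc(C(F)(F)F)cc(C(F)(F)F)c1`, which gives 10500 nM, a number beyond the scatter from compound 2 and the highest of the set.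

Compound 4 `Cc1ccc(-c2ccsc2S(=O)(=O)NCCNC(=O)Nc2cc(Cl)cc(Cl)c2)c(Oc2ccc(O)c(O)c2)c1` is the next entry to be measured in this assay. Relative to compound 2 the difference is a group of 11 heavy atoms (7 carbon, 1 nitrogen, 1 oxygen, 2 chlorine; one six-membered aromatic ring of carbon only) in place of a group of 11 heavy atoms (8 carbon, 1 nitrogen, 1 oxygen, 1 sulfur; one six-membered aromatic ring of carbon only), on an amine nitrogen. For the measured compounds named here, no step between two measured compounds matches this exchange, so there is no directly comparable shift to lean on. The measured spread of the three neighbours is narrow, and the terminus of compound 4 sits between those of compound 1 and compound 3 in kind, so the expected step of a 1.2-fold higher number from compound 2 to compound 4 (0.09 log units; within the scatter) is small and not beyond the scatter. Compound 4 is therefore estimated at 5000 nM, with a range from 2000 nM to 12000 nM.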

Compound 4, half-maximal inhibitory concentration: 3500 nM
For compound 4 the middle estimate is 1.4-fold (0.15 log units) above the measured one; the measured number falls inside the stated range.
By their numbers in this assay, from the lowest: compounds 1, 4 and 2 (each within the scatter of the next); then compound 3.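

In this assay, the exchange for (3,5-dichlorophenyl)carbamoyl on the amine nitrogen gives a 1.2-fold lower number from compound 2 to compound 4 (0.07 log units; within the scatter), the first step read at this position. For the compounds shown here, two different ring-bearing groups, one with sulfur and one with two chlorines, therefore give numbers that cannot be told apart here, although the single step cannot show how far this holds for other groups. The exchange alters the sulfur-bearing part and the ring substituents together, so the step cannot be assigned to either, and no measurement at hand explains it.

As far as these compounds go, it remains open whether a group without a ring, such as acetyl, would keep the number in the same range at this nitrogen. Also open, from the compounds shown here alone, is how a carboxylic acid or an amine on the terminal ring would read.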